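Methyl added on the piperidin-1-yl ring of compound 3

The compounds below may be only part of what the source reports. "The series", "measured", "known", "first", "only" and "open" are said of these compounds alone.

Working notes on the series. Of the compounds shown here, three sharing one core have been measured in a functional assay on A549 cells (Homo sapiens) for inhibition, read by MTT assay, with a stated time of 72 h; a higher number here means a weaker inhibitor, a lower number a stronger inhibitor. Compound 1 `COc1cc2c(Oc3ccc(NC(=O)c4nn(-c5ccccc5)c(=O)cc4C)cc3F)ccnc2cc1OCCCN1CCCCC1` gives 150 nM. Compound 2 `COc1cc2c(Oc3ccc(NC(=O)c4nn(-c5ccccc5C)c(=O)cc4C)cc3F)ccnc2cc1OCCCN1CCCC1` gives 1300 nM. Compound 3 `COc1cc2c(Oc3ccc(NC(=O)c4nn(-c5ccccc5C)c(=O)cc4C)cc3F)ccnc2cc1OCCCN1CCCCC1` gives 1920 nM. Compound 3 stands beyond the scatter above compound 1, with a 13-fold higher number from compound 1 to compound 3 (1.11 log units; beyond the scatter), and within the scatter of compound 2, with a 1.5-fold higher number from compound 2 to compound 3 (0.17 log units; within the scatter).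

The next compound, compound 4 `COc1cc2c(Oc3ccc(NC(=O)c4nn(-c5ccccc5C)c(=O)cc4C)cc3F)ccnc2cc1OCCCN1CCC(C)CC1`, differs from compound 3 by methyl in place of hydrogen on a saturated ring carbon, the saturated ring being the piperidin-1-yl group, giving 4-methylpiperidin-1-yl. Of the two measured steps, only the change from pyrrolidin-1-yl to piperidin-1-yl in this assay bears on the same end of the molecule, and that step stayed within the scatter. The large step from compound 1 to compound 3 concerns a methyl on an aromatic carbon elsewhere and does not speak to this change. No step beyond the scatter is therefore expected in this assay for compound 4, in either direction.

Compound 4 is expected to give an estimated 2000 nM in this assay, within a range from 900 nM to 4500 nM. This expectation corresponds to an estimated 1.0-fold higher number from compound 3 to compound 4 (0.02 log units; within the scatter).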

Compound 4, half-maximal inhibitory concentration: 1460 nM
Beside the measured number, compound 4's estimate is 1.4-fold (0.14 log units) above it; the range from low to high includes it.
By their numbers in this assay, from the lowest: compound 1; then compounds 2, 4 and 3 (each within the scatter of the next).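

In this assay, methyl in place of hydrogen on a saturated ring carbon, three ring bonds from the ring nitrogen, gives a 1.3-fold lower number from compound 3 to compound 4 (0.12 log units; within the scatter) and so shows that the piperidin-1-yl group takes this added methyl with no step beyond the scatter. The swap of pyrrolidin-1-yl for 4-methylpiperidin-1-yl gives a 1.1-fold higher number from compound 2 to compound 4 (0.05 log units; within the scatter) and extends the earlier picture: the three amine groups measured so far, all on compounds that also carry the aromatic methyl, stay within the scatter of one another at this end of the molecule. No measurement on hand accounts for how closely these values lie.

Among the compounds shown here, whether the 4-methylpiperidin-1-yl group behaves the same way without the aromatic methyl remains open, as the only compound lacking that methyl, compound 1 at 150 nM in this assay, carries the plain piperidin-1-yl group. Also open, on these data alone, is whether this ring position would tolerate a hydroxyl or a carboxylic acid in place of the methyl, and whether a morpholin-4-yl group at the end of the chain would stay within the scatter of these amines.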